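Compound 4: thiophen-3-yl replaced by 1H-pyrrol-3-yl

A few compounds are considered here, and "the series" means these few. Any claim that something is new, unique, unknown or untested is made for them only; others in the source may bear on it.

In a functional assay on A-375 cells (Homo sapiens) for activation, with a stated time of 3 days (a lower number here means that less compound is needed, a higher number that more compound is needed for the effect), compound 1 (`O=C(Nc1ccc(-c2ccccc2)cc1)C1CCCN(Cc2ccc(F)c(F)c2)C1`) gives 5000 nM, compound 2 (`O=C(Nc1ccc(-c2ccccn2)cc1)C1CCCN(Cc2ccc(F)c(F)c2)C1`) gives 11000 nM and compound 3 (`O=C(Nc1ccc(-c2ccsc2)cc1)C1CCCN(Cc2ccc(F)c(F)c2)C1`) gives 1930 nM, the lowest of the three. Compound 4 (`O=C(Nc1ccc(-c2cc[nH]c2)cc1)C1CCCN(Cc2ccc(F)c(F)c2)C1`) carries 1H-pyrrol-3-yl in place of thiophen-3-yl on an aromatic carbon. Ring swaps at this place have produced modest steps: a 2.2-fold higher number from compound 1 to compound 2 (0.34 log units; beyond the scatter), a 2.6-fold lower number from compound 1 to compound 3 (0.41 log units; beyond the scatter) and a 5.7-fold lower number from compound 2 to compound 3 (0.76 log units; beyond the scatter). Within the data shown here, no measured compound carries 1H-pyrrol-3-yl. Only thiophen-3-yl has lowered the number, a 2.6-fold lower number from compound 1 to compound 3 (0.41 log units; beyond the scatter), and that drop need not carry over to another five-membered ring. A modest upward step is therefore expected, a 2.1-fold higher number from compound 3 to compound 4 (0.32 log units; beyond the scatter). For compound 4 the estimated value is 4000 nM, with an expected range of 1500 nM to 11000 nM.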

Compound 4, half-maximal effective concentration: 2610 nM
Compound 4: the middle estimate sits 1.5-fold (0.19 log units) above what was measured; measured number inside the range.
By their numbers in this assay, from the lowest: compounds 3, 4 and 1 (each within the scatter of the next, the first and the last beyond it); then compound 2.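

In this assay, the change from thiophen-3-yl to 1H-pyrrol-3-yl, which brings in a hydrogen-bond donor, stays within the scatter: a 1.4-fold higher number from compound 3 to compound 4 (0.13 log units; within the scatter). The step from phenyl also stays within it: a 1.9-fold lower number from compound 1 to compound 4 (0.28 log units; within the scatter). Among these compounds, only the step from pyridin-2-yl lies beyond it, a 4.2-fold lower number from compound 2 to compound 4 (0.62 log units; beyond the scatter), and nothing available explains these differences. Still open, as far as these compounds go, is how the number responds to a methyl group on the pyrrole nitrogen, or to an amine or a carboxylic acid on the five-membered ring.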